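The compounds below may be only part of what the source reports. "The series", "measured", "known", "first", "only" and "open" are said of these compounds alone.

Compound 1 `Oc1ccc(-c2cc(-c3ccccc3C(F)(F)F)cc(-c3cccc(O)c3)n2)cc1`: 2750 nM
Compound 2 `Oc1ccc(-c2cc(-c3cccc(C(F)(F)F)c3)cc(-c3cccc(O)c3)n2)cc1`: 11100 nM

Both numbers come from a functional assay on DU-145 cells (Homo sapiens) for inhibition (a higher number here means a weaker inhibitor, a lower number a stronger inhibitor), in which compound 1 gives 2750 nM and compound 2 gives 11100 nM. For the measured compounds named here, compound 2 thus stands at the higher of the two numbers, set apart from compound 1 by the one measured step, a 4.0-fold higher number from compound 1 to compound 2 (0.61 log units; beyond the scatter), which is described as modest and lies beyond the scatter.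

Compound 3 `Oc1ccc(-c2cc(-c3ccc(C(F)(F)F)cc3)cc(-c3cccc(O)c3)n2)cc1` differs from compound 2 by 4-(trifluoromethyl)phenyl in place of 3-(trifluoromethyl)phenyl on an aromatic carbon. Going by the values given here, no measured step covers this particular exchange; the only guide is the step from compound 1 to compound 2, which weakened inhibition by a modest amount. On that basis the change from compound 2 to compound 3 is expected to alter the number in this assay by a 1.2-fold higher number from compound 2 to compound 3 (0.07 log units; within the scatter), a step that may well remain within the scatter. Compound 3 is therefore estimated to give about 13000 nM in this assay, with a range from 4500 nM to 40000 nM.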

Compound 3, half-maximal inhibitory concentration: > 50000 nM
Compound 3: only a limit was reported; the forecaster's own chance of this, stated with the estimate: 10%; at least 3.8-fold (0.58 log units) between middle value and limit.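

For compound 3, this assay yields only a limit and not a number: the limit of > 50000 nM in this assay, at which 1 of the 3 values shown sits.
With 4-(trifluoromethyl)phenyl in place of 3-(trifluoromethyl)phenyl, the change is an at least 4.5-fold higher number from compound 2 to compound 3 (0.65 log units; beyond the scatter), and with 4-(trifluoromethyl)phenyl in place of 2-(trifluoromethyl)phenyl, it is an at least 18-fold higher number from compound 1 to compound 3 (1.25 log units; beyond the scatter). The same atoms joined differently thus give a third distinct outcome at this position on the shared core, and the series now runs in one direction, from 2-(trifluoromethyl)phenyl through 3-(trifluoromethyl)phenyl to 4-(trifluoromethyl)phenyl, the weakest inhibitor of the three.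

From the compounds shown here alone, how far compound 3 lies past its limit remains unknown, so both of its steps have only a lower bound. Also open, going by these compounds, is whether a phenyl carrying a methoxy group, a chlorine or a nitrile would follow the same order across these three placements.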